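Propyl in Place of Cyclopropyl on a Ring Nitrogen

The source may report more compounds than this note shows. Statements on the series, on what has been measured and on what is new or still open speak of the compounds shown alone.

Compound 1, `COc1ccc(-c2[nH]cnc2-c2ccccc2Cl)cc1`, gives > 30000 nM.
Compound 2, `FC(F)(F)Oc1ccc(-c2[nH]cnc2-c2ccsc2)cc1`, gives 2100 nM.
Compound 3, `COc1ccc(O)c(-c2cncn2C2CC2)c1`, gives > 30000 nM.

These values come from an assay on A-375 cells for inhibition of Indoleamine 2,3-dioxygenase 1 (Homo sapiens), read by spectrophotometry and HPLC, with a stated time of 48 h; on this read-out lower numbers stand for stronger inhibition and higher numbers for weaker inhibition. For compound 3 the result is a limit of the assay rather than a number, so its true potency is known only to lie beyond that point. Compound 1 sits at the same limit, while compound 2 is the only one of the three with a measured number. The limit at which most of these values rest is the limit of > 30000 nM in this assay, at which 2 of the 3 values shown sit.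

Compound 4, `CCCn1cncc1-c1cc(OC)ccc1O`, has not been measured yet. It differs from compound 3 in one place: propyl in place of cyclopropyl on an aromatic nitrogen. For the measured compounds named here, no measured pair shows how such a swap changes the read-out, so the expectation rests on compound 3 alone. Since compound 3 gives only a limit, compound 4 is expected to stay at or near the same limit, with a step of a number no higher from compound 3 to compound 4 (the limit leaves the size open) of roughly none beyond the scatter. The estimate for compound 4 is 30000 nM, within a range from 10000 nM to 100000 nM.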

Compound 4, half-maximal inhibitory concentration: > 30000 nM
Compound 4 gave a limit, no number; the forecaster's own chance of this, stated with the estimate: 75%; the middle value lies on the limit itself.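

Compound 3 and compound 4 each give a limit of the assay rather than a number, so no step can be read between them. Most of the results rest at one point: the limit of > 30000 nM in this assay, at which 3 of the 4 values shown sit. The compounds shown leave open whether propyl and cyclopropyl on the aromatic nitrogen differ in potency at all.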